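The source may hold more compounds than are shown below. What is called first, only, known or untested is meant among the compounds shown, and "the series" means these compounds.

Measured so far in a functional assay on the whole organism (strain Swiss) with Mus musculus as the target, in the maximal electroshock model, with a stated time of 0.25 h, at a dose of 100 mg/kg by the intraperitoneal route; on this read-out higher numbers stand for a stronger effect at the one dose given and lower numbers for a weaker effect:
compound 1, `CCC(C(=O)N1CCN(c2cccc(F)c2)CC1)N1C(=O)CCC1=O`, gives 0%.
compound 2, `CCC(C(=O)N1CCN(c2cccc(C(F)(F)F)c2)CC1)N1C(=O)CCC1=O`, gives 75%.
compound 3, `CCC(C(=O)N1CCN(c2cccc(C)c2)CC1)N1C(=O)CCC1=O`, gives 50%.

Compound 3 stands second highest of the three numbers in this assay. Its position is fixed by two steps: a number 25 percentage points lower from compound 2 to compound 3 (beyond the scatter), and a number 50 percentage points higher from compound 1 to compound 3 (beyond the scatter). The third step, a number 75 percentage points higher from compound 1 to compound 2 (beyond the scatter), shows that the substituent on the phenyl ring is the only thing varied so far, with fluoro far below methyl and trifluoromethyl.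

Compound 4, `CCC(C(=O)N1CCN(c2cccc(Cl)c2)CC1)N1C(=O)CCC1=O`, differs from compound 3 by chloro in place of methyl on an aromatic carbon. For the measured compounds named here, no measured step exchanges methyl for chloro, so none bears on it directly; the three known steps only show that the read-out is sensitive to which group sits at this position, by large margins. Chloro is an untested group, so the expectation is loose. Compound 4 is expected to come out near compound 3, with the expected step of a number 10 percentage points higher from compound 3 to compound 4 (within the scatter) not clearly beyond the scatter in either direction. The estimate for compound 4 in this assay is 60%, within a range of 25% to 100%.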

Compound 4, a percentage reported as activity, at one dose (the size of the read-out at that dose, not a potency): 50%
Beside the measured number, compound 4's estimate is 10 percentage points above it; measured number inside the range.
By their numbers in this assay, from the lowest: compound 1; then compounds 3 and 4 (each within the scatter of the next); then compound 2.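

In this assay, chloro in place of methyl gives no change at the digits printed from compound 3 to compound 4 (within the scatter), so this position does not tell these two groups apart. The two halogens are told apart: chloro in place of fluoro gives a number 50 percentage points higher from compound 1 to compound 4 (beyond the scatter), so the low value of compound 1 does not extend to every halogen here. Trifluoromethyl stays separate from chloro, as it did from methyl, with a number 25 percentage points lower from compound 2 to compound 4 (beyond the scatter), which leaves compound 2 clear of both compound 3 and compound 4.

Nothing available explains why these groups separate as they do. As far as these compounds go, it also remains open whether bromo, methoxy, a nitrile or an amine at this position would fall with compound 3 and compound 4, reach compound 2 or drop towards compound 1.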